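Triazole substituent exchange on the shared core

This account rests on a few compounds, and the source may have more. Where it says the series, first, only, none or still open, it means among the compounds named here.

Measured so far:
compound 1, `O=C1NC(O)(CCn2cc(C3=CCCCC3)nn2)C(OCc2ccccc2)=C1OCc1ccccc1`, 67200 nM
compound 2, `CC(C)(C)c1ccc(-c2cn(C/C=C3\OC(=O)C(OCc4ccccc4)=C3OCc3ccccc3)nn2)cc1`, > 100000 nM
compound 3, `COC1=C(OC)C(O)(CCn2cc(-c3ccccc3)nn2)NC1=O`, 35300 nM

In a functional assay on PC-3 cells (Homo sapiens) for antiproliferative activity, read by MTT assay, with a stated time of 24 h (a higher number here means a weaker inhibitor, a lower number a stronger inhibitor), compound 1 gives 67200 nM and compound 3 gives 35300 nM. For compound 2 this assay records only a limit, > 100000 nM, so compound 2 stands at the edge of what the assay reports, as captured by the limit of > 100000 nM in this assay, at which 1 of the 3 values shown sits. Its place on the numbers is therefore undefined beyond that edge.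

Compound 4, `O=C1O/C(=C\Cn2cc(C3=CCCCC3)nn2)C(OCc2ccccc2)=C1OCc1ccccc1`, is still to be measured in this assay. It differs from compound 2 in a single place: cyclohex-1-en-1-yl in place of 4-(tert-butyl)phenyl on an aromatic carbon. Going by the values given here, no step between measured compounds covers this change, so neither its direction nor its size is documented. Compound 4 may nonetheless fall back inside the measurable range, since compound 1 carries the same cyclox-1-en-1-yl group on a different core and gives 67200 nM. The step from compound 2 to compound 4 is expected to be an at least 1.2-fold lower number from compound 2 to compound 4 (0.09 log units; that floor lies within the scatter), modest and not clearly beyond scatter. Compound 4 is estimated at 80000 nM with a range from 30000 nM to 200000 nM, with a real chance that this assay again returns only a limit.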

Compound 4, half-maximal inhibitory concentration: 55600 nM
The estimate for compound 4 lay 1.4-fold (0.16 log units) above the measured number; the range from low to high includes it.
By their numbers in this assay, from the lowest: compounds 3, 4 and 1 (each within the scatter of the next). At a limit, above all of these: compound 2.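

In this assay, going by these compounds alone, cyclohex-1-en-1-yl in place of 4-(tert-butyl)phenyl on an aromatic carbon of the five-membered aromatic ring with 3 nitrogen gives an at least 1.7-fold lower number from compound 2 to compound 4 (0.25 log units; that floor lies within the scatter); this is the first step documented at this position, and it turns a reading at the edge of the assay into a measured number. The size of this step is known only as a floor, and no upper bound can be given, because compound 2 is recorded only as a limit: the limit of > 100000 nM in this assay, at which 1 of the 4 values shown sits. The change also alters two things at once, as the group that leaves has 10 heavy atoms and an aromatic ring, while the group that enters has 6 heavy atoms and a non-aromatic ring, so this single step cannot separate ring type from group size.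

Still open, going by these compounds, is how far the true value of compound 2 lies from its limit, and with it the real size of the step. Also open, on these data alone, is how a saturated cyclohexyl group or a piperidine ring on the same aromatic carbon of the shared core would read in this assay.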